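Compound 2 to compound 3: piperidine amine substituent

The compounds below may be only part of what the source reports. "The series", "measured", "known", "first", "only" and "open" are said of these compounds alone.

Measured so far in an ADME assay on liver for metabolic stability, with Liver microsome (Homo sapiens) as the target, using microsomes; on this read-out higher numbers stand for fast clearance and lower numbers for slow clearance
- compound 1 `CC(=O)Nc1cc(Nc2cc(NC3CC3)n3ncc(C#N)c3n2)ccc1N1CC[C@H](N(C)C)C1` gives 9 mL.min-1.g-1
- compound 2 `CC(=O)Nc1cc(Nc2cc(NC3CC3)n3ncc(C#N)c3n2)ccc1N1CCC[C@@H](N(C)C)C1` gives 19 mL.min-1.g-1

Of these two numbers, compound 2 stands highest at 19 mL.min-1.g-1. The next structure, compound 3 `CC(=O)Nc1cc(Nc2cc(NC3CC3)n3ncc(C#N)c3n2)ccc1N1CCC[C@H](N)C1`, has not yet been measured. Its difference from compound 2 is a group of 7 heavy atoms (5 carbon, 2 nitrogen; one six-membered non-aromatic ring with 1 hetero atom) in place of a group of 9 heavy atoms (7 carbon, 2 nitrogen; one six-membered non-aromatic ring with 1 hetero atom), on an aromatic carbon. The entering group is 3-aminopiperidin-1-yl, on an aromatic carbon ortho to an acetamido group and para to a large group.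

Among the compounds with values here, only one measured step bears on this change, and only indirectly: a 2.1-fold higher number from compound 1 to compound 2 (0.32 log units; beyond the scatter). This modest step goes with a larger group and a six-membered ring in place of a five-membered one. Within the data shown here, in compound 3 the six-membered ring stays and the group gets smaller, so no measured step makes the same change. From that single step, a modest move to a lower number is expected in this assay, with low confidence. The expected size is a 1.9-fold lower number from compound 2 to compound 3 (0.28 log units; within the scatter). Compound 3 is estimated at 10 mL.min-1.g-1, with an expected range of 5 mL.min-1.g-1 to 20 mL.min-1.g-1.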

Compound 3, intrinsic clearance in microsomes: < 3 mL.min-1.g-1
Compound 3: no number, only a limit (the forecaster's own chance of this, stated with the estimate: 5%); middle value at least 3.3-fold (0.52 log units) away from the limit.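

In this assay, compound 3 gives a limit of the assay and not a number: the limit of < 3 mL.min-1.g-1 in this assay, at which 1 of the 3 values shown sits.

With the six-membered ring held constant, 3-aminopiperidin-1-yl in place of the dimethylamino-bearing piperidine gives an at least 6.3-fold lower number from compound 2 to compound 3 (0.80 log units; beyond the scatter), so the substituent on this ring moves the read-out at this aromatic carbon, ortho to the acetamido group, and not only the ring size seen in a 2.1-fold higher number from compound 1 to compound 2 (0.32 log units; beyond the scatter). Against 3-(dimethylamino)pyrrolidin-1-yl, the entering group also gives an at least 3.0-fold lower number from compound 1 to compound 3 (0.47 log units; beyond the scatter), so a six-membered ring at this position does not by itself go with the higher number.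

The compounds shown leave open whether the lower number follows from the amine carrying its hydrogens or from the smaller group as a whole, since the two change together in this step. A 3-(methylamino)piperidin-1-yl group or a 3-aminopyrrolidin-1-yl group on this aromatic carbon would separate these two readings and show whether the ring size still counts once the amine is unsubstituted.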